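Swapping the aryl ether for isobutyl on the shared core

A few compounds are considered here, and "the series" means these few. Any claim that something is new, unique, unknown or untested is made for them only; others in the source may bear on it.

Compound 1, `COc1ccc(F)cc1CNCCCNc1ccnc2cc(Cc3ccc(F)cc3Cl)ccc12`, gives 9.47 in a physicochemical assay for acid dissociation.
Compound 2, `CN(C)c1cccc(Oc2ccc3c(NCCCNCc4ccco4)ccnc3c2)c1`, gives 9.28.
Compound 3, `COc1ccc(F)cc1CNCCCNc1ccnc2cc(Oc3cccc(N(C)C)c3)ccc12`, gives 9.28.

Compound 3 shares its reading with compound 2, and the two sit together at the low end of the three numbers, with compound 1 the furthest away: a number 0.19 log units lower from compound 1 to compound 3 (within the scatter), and no change at the digits printed from compound 2 to compound 3 (within the scatter). Neither step leaves the scatter, so the three compounds cannot be placed in any order.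

Compound 4, `COc1ccc(F)cc1CNCCCNc1ccnc2cc(CC(C)C)ccc12`, differs from compound 3 in one place: isobutyl in place of 3-(dimethylamino)phenoxy on an aromatic carbon. Within the data shown here, the only measured step that touches the same aromatic carbon of the core is a number 0.19 log units lower from compound 1 to compound 3 (within the scatter), which stayed within the scatter; the step of no change at the digits printed from compound 2 to compound 3 (within the scatter) concerns the other end of the molecule and says nothing about this position. On that footing the step to compound 4 is expected to be small, a number 0.12 log units higher from compound 3 to compound 4 (within the scatter), with no change beyond the scatter foreseen. Compound 4 is therefore estimated at 9.4, with a range from 9.1 to 9.7.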

Compound 4, acid dissociation constant: 9.47
Compound 4: middle estimate off by 0.07 log units, on the low side; the measured number falls inside the stated range.
By their numbers in this assay, from the lowest: compounds 2, 3, 1 and 4 (each within the scatter of the next).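

Every group seen earlier at this aromatic carbon carried a six-membered aromatic ring, whereas isobutyl has no ring and no hydrogen-bond acceptors, and in this assay the exchange for 3-(dimethylamino)phenoxy gives a number 0.19 log units higher from compound 3 to compound 4 (within the scatter). Replacing the 2-chlorophenyl-type end of compound 1 in the same way, with isopropyl in place of 2-chloro-4-fluorophenyl on the saturated chain carbon, gives no change at the digits printed from compound 1 to compound 4 (within the scatter), so the reading at this position has not separated across an aryl ether, a substituted benzyl and isobutyl. No measurement shown explains this lack of separation.

From the compounds shown here alone, whether a carboxylic acid or a primary amine on this aromatic carbon would also stay within the scatter in this assay remains open. So does the reading for a longer chain or a bare hydrogen there.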